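This account rests on a few compounds, and the source may have more. Where it says the series, first, only, none or still open, it means among the compounds named here.

Measured so far: compound 1 `CCN(CC)C(=O)CNC1CC2(N3CCN(C)CC3)CC(c3ccccc3)C1C(c1ccccc1)C2`, compound 2 `CCN(CC)CCCN1CCC2(N3CCN(C)CC3)CC(c3ccccc3)C1C(c1ccccc1)C2` and compound 3 `CCN(CC)CCC(=O)NC1CC2(N3CCN(C)CC3)CC(c3ccccc3)C1C(c1ccccc1)C2`.

In an ADME assay on L6 cells (Rattus norvegicus) for cytotoxicity, read by fluorescence, with a stated time of 72 h (on this read-out lower numbers stand for stronger inhibition and higher numbers for weaker inhibition), compound 1 gives 37900 nM, compound 2 gives 68100 nM and compound 3 gives 35900 nM. The three numbers sit close together; compound 3 lies within the scatter of both compound 1 and compound 2, so no ordering among them is supported.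

Compound 4 `CN1CCN(C23CC(NC(=O)CCN4CCCC4)C(C(c4ccccc4)C2)C(c2ccccc2)C3)CC1` differs from compound 3 in one place: pyrrolidin-1-yl in place of diethylamino on a saturated chain carbon, two bonds along the chain from a carbonyl carbon.

Among the measured compounds shown here, the only measured step that touches this region of the molecule is a 1.1-fold lower number from compound 1 to compound 3 (0.02 log units; within the scatter), which reworked the amine-side chain without moving the number beyond the scatter. For the measured compounds named here, no measured pair swaps an open-chain amine for a ring amine, so the step to compound 4 is expected to stay within the scatter, with no direction assigned: a 1.0-fold higher number from compound 3 to compound 4 (0.00 log units; within the scatter). Compound 4 is accordingly estimated at 36000 nM, between 18000 nM and 72000 nM.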

Compound 4, half-maximal inhibitory concentration: 42200 nM
For compound 4 the middle estimate is 1.2-fold (0.07 log units) below the measured one, and the stated range covers the measured number.
By their numbers in this assay, from the lowest: compounds 3, 1, 4 and 2 (each within the scatter of the next).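

Among the compounds shown here, the first swap of an open-chain amine for a ring amine, pyrrolidin-1-yl in place of diethylamino on a saturated chain carbon, two bonds along the chain from a carbonyl carbon, gives in this assay a 1.2-fold higher number from compound 3 to compound 4 (0.07 log units; within the scatter). The larger replacement, (2-(pyrrolidin-1-yl)ethyl)carbonyl in place of (diethylcarbamoyl)methyl on an amine nitrogen, gives a 1.1-fold higher number from compound 1 to compound 4 (0.05 log units; within the scatter). No evidence on the origin of these results is available.

From the compounds shown here alone, whether morpholine or piperidine at this place, or a longer chain carrying the amine, would give a number beyond the scatter stays open.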